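The source may report more compounds than this note shows. Statements on the series, on what has been measured and on what is new or still open speak of the compounds shown alone.

In a functional assay on HT-1080 cells (Homo sapiens) for cytotoxicity, read by MTT assay, with a stated time of 72 h (on this read-out lower numbers stand for stronger inhibition and higher numbers for weaker inhibition), three compounds sharing one core have been measured. Compound 1 (`COc1ccccc1/C=C1\CCC/C(=C\c2ccc(OC)c(OC)c2)C1=O`) gives 8100 nM and compound 2 (`COc1ccc(/C=C2\CCC/C(=C\c3ccc(OC)c(OC)c3)C2=O)cc1`) gives 7200 nM, a pair separated by a 1.1-fold lower number from compound 1 to compound 2 (0.05 log units; within the scatter). Compound 3 (`COc1ccc(/C=C2\CCC/C(=C\c3ccc(O)cc3)C2=O)cc1OC`) gives 16800 nM, the highest number of the three and thus the weakest inhibition among them.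

Compound 4 (`COc1ccc(/C=C2\CCC/C(=C\c3ccc(Cl)c(Cl)c3)C2=O)cc1OC`) has not yet been measured. It differs from compound 3 as follows: 3,4-dichlorophenyl in place of 4-hydroxyphenyl on a double-bonded chain carbon bound to a double-bonded ring carbon. In words, 3,4-dichlorophenyl stands in place of 4-hydroxyphenyl on a double-bonded chain carbon bound to a double-bonded ring carbon.

Going by the values given here, no measured compound carries chlorine, so the data offer no direct precedent for this change. The nearest evidence concerns the group that leaves. Compound 3 alone carries 4-hydroxyphenyl, and the two steps that lead to it both raise the number: a 2.3-fold higher number from compound 2 to compound 3 (0.37 log units; beyond the scatter) and a 2.1-fold higher number from compound 1 to compound 3 (0.32 log units; beyond the scatter). Both are modest. If removing 4-hydroxyphenyl roughly reverses them, a modest fall would be expected in this assay, although the entering group is untested. The expected step is a 2.6-fold lower number from compound 3 to compound 4 (0.41 log units; beyond the scatter). The estimate for compound 4 is 6500 nM, with an expected range from 2500 nM to 15000 nM.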

Compound 4, half-maximal inhibitory concentration: 3100 nM
Beside the measured number, compound 4's estimate is 2.1-fold (0.32 log units) above it, within the range that was stated.
By their numbers in this assay, from the lowest: compound 4; then compounds 2 and 1 (each within the scatter of the next); then compound 3.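

In this assay, going by these compounds alone, the place on a double-bonded chain carbon bound to a double-bonded ring carbon now shows a larger swing than the earlier compounds revealed, with 3,4-dichlorophenyl giving a 5.4-fold lower number from compound 3 to compound 4 (0.73 log units; beyond the scatter) against the earlier 2.3-fold higher number from compound 2 to compound 3 (0.37 log units; beyond the scatter) for the change on the oxygen. The earlier compounds shown here showed only that 4-hydroxyphenyl gave a higher number than the methoxyphenyl groups, whereas 3,4-dichlorophenyl also goes below those groups, with a 2.3-fold lower number from compound 2 to compound 4 (0.37 log units; beyond the scatter) and a 2.6-fold lower number from compound 1 to compound 4 (0.42 log units; beyond the scatter), leaving compound 4 with the lowest number of the four, beyond the scatter of each of the others. Nothing available here accounts for the fall in the number.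

The compounds shown leave open whether both chlorines are needed, since neither 4-chlorophenyl nor 3-chlorophenyl stands among them, and whether another halogen, as in 3,4-difluorophenyl or 3,4-dibromophenyl, would do the same. They also leave open how a group of another kind, such as 4-aminophenyl or 4-carboxyphenyl, would behave at this place.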